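This account rests on a few compounds, and the source may have more. Where it says the series, first, only, none or still open, it means among the compounds named here.

Working notes on the pyrazolidinone series in an assay on isolated protein for inhibition of Polyunsaturated fatty acid 5-lipoxygenase (Rattus norvegicus); a higher number here means a weaker inhibitor, a lower number a stronger inhibitor.

Compound 1 `CCCOCC1CN(c2ccccc2)NC1=O` carries a propoxy group on the saturated chain carbon bound to the ring and gives 260 nM. Compound 2 `CCOCCC1CN(c2ccccc2)NC1=O` carries an ethoxy group one bond further along the chain; compound 2 gives 150 nM. The step of a 1.7-fold lower number from compound 1 to compound 2 (0.24 log units; within the scatter) stays within the scatter. Compound 3 `CN(C)CCC1CN(c2ccccc2)NC1=O` carries a dimethylamino group at that same outer chain position. In this assay compound 3 gives > 1000 nM, which is a limit of the assay and not a number (the limit of > 1000 nM in this assay, at which 1 of the 3 values shown sits). The steps of an at least 3.8-fold higher number from compound 1 to compound 3 (0.58 log units; beyond the scatter) and an at least 6.6-fold higher number from compound 2 to compound 3 (0.82 log units; beyond the scatter) therefore mark compound 3 as the weakest of the three measured compounds.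

Compound 4 `O=C1NN(c2ccccc2)CC1Cc1cccs1` is the next one to be measured. It differs from compound 3 by thiophen-2-yl in place of (dimethylamino)methyl on a saturated chain carbon bound to a saturated ring carbon. Within the data shown here, both measured steps onto compound 3 went up on replacing an ether by the dimethylamino group; removing that group again is expected to reverse them, and a thiophene ring has no counterpart among the measured compounds. The step of an at least 5.0-fold lower number from compound 3 to compound 4 (0.69 log units; beyond the scatter) is therefore expected to bring compound 4 back into the region of compound 1 and compound 2. Compound 4 is estimated at 200 nM, with a range from 60 nM to 800 nM.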

Compound 4, half-maximal inhibitory concentration: 140 nM
Compound 4: the middle estimate sits 1.4-fold (0.15 log units) above what was measured; low and high end bracket the measured number.
By their numbers in this assay, from the lowest: compounds 4, 2 and 1 (each within the scatter of the next). At a limit, above all of these: compound 3.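

In this assay, the position on the saturated chain carbon bound to a saturated ring carbon accepts an aromatic ring as well as an ether chain: thiophen-2-yl cannot be told apart from either ether side chain (a 1.1-fold lower number from compound 2 to compound 4 (0.03 log units; within the scatter); a 1.9-fold lower number from compound 1 to compound 4 (0.27 log units; within the scatter)). The side chain of compound 4 contains no ether oxygen, so that oxygen is not required for a value in this range, and the loss seen with the dimethylamino group is not a general penalty for changing the ether chain, as the return from that group shows (an at least 7.1-fold lower number from compound 3 to compound 4 (0.85 log units; beyond the scatter)). The value of compound 3 is a limit and not a number, so this last step gives only a lower bound on the true size of the change: the limit of > 1000 nM in this assay, at which 1 of the 4 values shown sits.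

On these data alone, whether the loss at compound 3 is specific to dimethylamino or extends to other nitrogen groups, such as a morpholine or a primary amine, stays open, as does the effect of a carboxylic acid at this position. Also open, as far as these compounds go, is whether the thiophene sulfur matters, which a phenyl or furan-2-yl ring in place of thiophen-2-yl would test.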